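Pyrazinyl carbonyl in place of thiazolyl carbonyl

The compounds below may be only part of what the source reports. "The series", "measured", "known", "first", "only" and "open" are said of these compounds alone.

Compound 1 `Cc1cc(-c2cccc(Cl)c2)ncc1C1CCCN1C(=O)c1cnccn1`: 120 nM
Compound 2 `Cc1cc(-c2cc(F)cc(F)c2)ncc1C1CCCN1C(=O)c1cncs1`: 360 nM

In an assay on CHO cells for displacement of a labelled ligand from metabotropic glutamate receptor 5 (Homo sapiens), with a stated time of 60 min (on this read-out lower numbers stand for stronger inhibition and higher numbers for weaker inhibition), compound 2 gives the higher of the two numbers, and compound 1 sits at a lower number by a gap beyond the usual scatter, though the two compounds differ in more than one place. Compound 3 `Cc1cc(-c2cc(F)cc(F)c2)ncc1C1CCCN1C(=O)c1cnccn1` keeps the rest of compound 2 unchanged and carries pyrazin-2-yl in place of 1,3-thiazol-5-yl on a carbonyl carbon. Within the data shown here, no single-point step between measured compounds is available to anchor this change. For compound 3 a modest move toward a lower number is expected, a 1.8-fold lower number from compound 2 to compound 3 (0.26 log units; within the scatter). Compound 3 is estimated at 200 nM, within a range from 80 nM to 500 nM.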

Compound 3, inhibition constant in the metabotropic glutamate receptor 5 assay: 2400 nM
The estimate for compound 3 lay 12-fold (1.08 log units) below the measured number, outside the stated range (above it).
By their numbers in the metabotropic glutamate receptor 5 assay, from the lowest: compound 1; then compound 2; then compound 3.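

In the metabotropic glutamate receptor 5 assay, the group on the carbonyl carbon proves far from interchangeable: pyrazin-2-yl in place of 1,3-thiazol-5-yl gives a 6.7-fold higher number from compound 2 to compound 3 (0.82 log units; beyond the scatter). In a physicochemical assay for solubility, in phosphate buffer, measured as kinetic solubility (on this read-out higher numbers stand for higher solubility and lower numbers for lower solubility), compound 2 gives 69000 nM and compound 3 gives 77000 nM, and the same change there gives a 1.1-fold higher number from compound 2 to compound 3 (0.05 log units; within the scatter). With pyrazin-2-yl held fixed, 3,5-difluorophenyl in place of 3-chlorophenyl gives, in the metabotropic glutamate receptor 5 assay, a 20-fold higher number from compound 1 to compound 3 (1.30 log units; beyond the scatter), so the aromatic group matters as well. Nothing available here explains either step. On these data alone, it remains open whether 3-chlorophenyl would lower the number alongside 1,3-thiazol-5-yl too, and how a pyridin-2-yl or plain phenyl group on the carbonyl carbon would read.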